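Phenethyl in place of 3-chlorophenyl on the shared core

A few compounds are considered here, and "the series" means these few. Any claim that something is new, unique, unknown or untested is made for them only; others in the source may bear on it.

Of the compounds shown here, three sharing one core have been tested in a functional assay on HT-29 cells (Homo sapiens) for cytotoxicity, read by sulforhodamine B assay, with a stated time of 2 days, tested at 100 uM; on this read-out higher numbers stand for more inhibition at the one concentration tested (going by the name of the read-out) and lower numbers for less inhibition. Compound 2 `O=C(Nn1c(-c2cccc([N+](=O)[O-])c2)nc2c(-c3cccc(Cl)c3)n[nH]c2c1=O)c1ccccc1` gives 89.8%, the second highest of the three numbers. Its nearest neighbour is compound 3 `COc1cccc(-c2nc3c(-c4cccc(Cl)c4)n[nH]c3c(=O)n2NC(=O)c2ccccc2)c1`, which gives 91%; the step of a number 1.2 percentage points higher from compound 2 to compound 3 (within the scatter) lies within the scatter. Compound 1 `O=C(Nn1c(-c2cccc([N+](=O)[O-])c2)nc2c(-c3ccc(Cl)cc3)n[nH]c2c1=O)c1cccnc1` differs from compound 2 in two places at once. Compound 1 gives only 15.1%. Compound 4 `O=C(Nn1c(-c2cccc([N+](=O)[O-])c2)nc2c(CCc3ccccc3)n[nH]c2c1=O)c1ccccc1` differs from compound 2 in a single place: phenethyl in place of 3-chlorophenyl on an aromatic carbon. Among the compounds with values here, no measured step touches this part of the core, so the one measured step, a methoxy for a nitro elsewhere, offers no guide to what this change will do. Compound 4 is therefore expected to give 70%, within a wide range from 30% to 95%. That estimate means an expected step of a number 19.8 percentage points lower from compound 2 to compound 4 (beyond the scatter), downward but uncertain.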

Compound 4, a percentage reported as inhibition, at one concentration (the size of the read-out at that concentration, not a potency): 89.7%
Compound 4: the middle estimate sits 19.7 percentage points below what was measured; the measured number falls inside the stated range.
By their numbers in this assay, from the lowest: compound 1; then compounds 4, 2 and 3 (each within the scatter of the next).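

Putting phenethyl in place of 3-chlorophenyl on this aromatic carbon gives a number 0.1 percentage points lower from compound 2 to compound 4 (within the scatter) in this assay. So this position accepts a chlorine-free group with its aromatic ring held away from the core on a chain, something the earlier compounds, which all carry a chlorophenyl here, could not show. No evidence in hand explains why the reading holds.

Going by these compounds, whether the position needs an aromatic ring at all stays open, since a simple methyl, a longer alkyl chain or an amine here could behave differently. A single tested concentration also leaves open whether compound 2 and compound 4 would separate at lower doses.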